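The compounds below may be only part of what the source reports. "The series", "measured", "known", "first", "only" and "open" are said of these compounds alone.

In a functional assay on BV-2 cells (Mus musculus) for inhibition, read by Griess assay, with a stated time of 24 h (on this read-out higher numbers stand for weaker inhibition and lower numbers for stronger inhibition), three compounds have been measured so far. Compound 1 `COc1ccc(Br)cc1-c1cc(CO)on1` reads > 200000 nM, which is a limit of the assay and not a number. Going by the values given here, compound 2 `C=CCc1ccc(OC)c(-c2cc(CN3CCN(C(=O)OC(C)(C)C)CC3)on2)c1` gives 76900 nM, the only true number in the set. Compound 3 `C=CCc1ccc(OC)c(-c2cc(CN3CCN(CC(=O)OCC)CC3)on2)c1` reads > 200000 nM, again a limit and not a number. Compound 3 therefore stands at the limit of > 200000 nM in this assay, at which 2 of the 3 values shown sit.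

The next compound is compound 4 `C=CCc1ccc(OC)c(-c2cc(CN3CCN(CC=C)CC3)on2)c1`, and the change leading to it is vinyl in place of ethoxycarbonyl on a saturated chain carbon bound to an amine nitrogen in a ring. Put another way, the (ethoxycarbonyl)methyl group of compound 3 gives way to allyl. Among the compounds with values here, the one measured step that bears on this change is an at least 2.6-fold higher number from compound 2 to compound 3 (0.41 log units; beyond the scatter). On these data alone, its true size is unknown, as it ends at a limit. Any visible step from compound 3 can only run towards a lower number. Compound 2, at 76900 nM, shows that this nitrogen can carry a group and still give a real value. A modest step towards stronger inhibition in this assay is therefore expected, although a second reading at the limit remains possible. The estimate amounts to an at least 1.6-fold lower number from compound 3 to compound 4 (0.22 log units; that floor lies within the scatter). Compound 4 is expected at 120000 nM. The estimated range for compound 4 runs from 40000 nM to 300000 nM.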

Compound 4, half-maximal inhibitory concentration: 111000 nM
For compound 4 the middle estimate is 1.1-fold (0.03 log units) above the measured one; measured number inside the range.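

In this assay, the amine nitrogen in a ring now carries a second group that gives a real value: with vinyl in place of ethoxycarbonyl on the saturated chain carbon bound to it, the result is an at least 1.8-fold lower number from compound 3 to compound 4 (0.25 log units; that floor lies within the scatter). Allyl and tert-butoxycarbonyl on this nitrogen cannot be told apart, with a 1.4-fold higher number from compound 2 to compound 4 (0.16 log units; within the scatter), so this position accepts two quite different groups with no change beyond the scatter, while the (ethoxycarbonyl)methyl group of compound 3 alone among the three reads at the limit. Compound 3 is a limit and not a number, so the step away from it is only a floor and its true size stays unknown: the limit of > 200000 nM in this assay, at which 2 of the 4 values shown sit.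

The compounds shown leave open whether a carboxylic acid in place of the ethoxycarbonyl, or a longer chain ending in the same ester, would also read at the limit or give a real value. They also leave open how a bare amine hydrogen or a benzyl group on this nitrogen would read against allyl and tert-butoxycarbonyl.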